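The compounds below may be only part of what the source reports. "The series", "measured", "known", "first", "only" and "open" are said of these compounds alone.

Measured so far:

compound 1, `c1ccc(CNCC2CCN(CCCc3c[nH]c4ccc(-n5cnnc5)cc34)CC2)cc1`, with 5.6 nM
compound 2, `c1ccc(C2CCCCN2C2CCN(CCCc3c[nH]c4ccc(-n5cnnc5)cc34)CC2)cc1`, with 4.7 nM

Both compounds were tested in an assay on CHO cells for agonist activity at 5-hydroxytryptamine receptor 1D (Homo sapiens), read by GTPgammaS binding; a lower number here means that less compound is needed, a higher number that more compound is needed for the effect. Compound 1 gives 5.6 nM, the higher of the two numbers, and compound 2 gives 4.7 nM. The gap between them lies within the usual scatter of this assay, so no order between the two can be read from it. Both share the same core and differ only in the group on a saturated ring carbon, so the part that matters here seems to tolerate a change of that group.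

Compound 3, `CN(Cc1ccsc1)C1CCN(CCCc2c[nH]c3ccc(-n4cnnc4)cc23)CC1`, has not been measured yet. Compared with compound 1 it carries methyl((thiophen-3-yl)methyl)amino in place of (benzylamino)methyl on a saturated ring carbon. Because compound 1 gives 5.6 nM and compound 2 gives 4.7 nM in this assay despite differing at this very position, the step from compound 1 to compound 3 is expected to be small, with no clear direction, so that the estimated change a 1.3-fold higher number from compound 1 to compound 3 (0.10 log units; within the scatter) stays within or near the scatter. Compound 3 is therefore expected to give about 7 nM, with a likely range from 2.5 nM to 20 nM.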

Compound 3, half-maximal effective concentration: 4.2 nM
Estimate against measurement, compound 3: 1.7-fold (0.22 log units) above; the range from low to high includes it.
By their numbers in this assay, from the lowest: compounds 3, 2 and 1 (each within the scatter of the next).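

In this assay, putting methyl((thiophen-3-yl)methyl)amino in place of (benzylamino)methyl on the saturated ring carbon gives a 1.3-fold lower number from compound 1 to compound 3 (0.12 log units; within the scatter), so this step cannot be told apart from no change at all. The step alters several things at once: a five-membered aromatic ring with 1 hetero atom enters where a six-membered aromatic ring of carbon only leaves, and the entering group has 0 hydrogen-bond donors where the leaving group has 1, so for this pair neither the all-carbon ring nor that donor is needed to keep the number at this level. No measurement shown explains why the number stays level.

All the groups shown at this position hold both an aromatic ring and an amine nitrogen, so it stays open how a group without the ring, such as a plain dimethylamino, or one carrying a carboxylic acid would behave. As far as these compounds go, it is also open whether each change within this step would leave the number level on its own, as a methyl(benzyl)amino group, with the six-membered ring kept, would help to show.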